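The compounds below may be only part of what the source reports. "The series", "measured", "known", "first", "only" and "open" are said of these compounds alone.

Of the compounds shown here, two with a shared core have been measured in a functional assay on MIA PaCa-2 cells (Homo sapiens) for inhibition, read by MTT assay, with a stated time of 72 h; on this read-out lower numbers stand for stronger inhibition of growth and higher numbers for weaker inhibition of growth. Compound 1 `O=S(=O)(NCCCCCCNCc1ccc(Br)cc1)c1ccc2c(c1)OCC2` gives 13000 nM. Going by the values given here, compound 2 `O=S(=O)(NCCCCCCNCc1ccc(Br)cc1)c1ccc2ccsc2c1` gives 6000 nM, the lowest of the two numbers, and the only measured step, a 2.2-fold lower number from compound 1 to compound 2 (0.34 log units; beyond the scatter), separates it from compound 1.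

Compound 3 `O=S(=O)(NCCCCCCNCc1ccc(Br)cc1)c1ccc(Cl)cc1` differs from compound 2 by a single change: 4-chlorophenyl in place of 1-benzothiophen-6-yl on a sulfonyl sulfur. Among the compounds with values here, no measured pair exchanges this kind of group, so the expectation rests only on the step from compound 1 to compound 2, which shows that changing the group on the sulfonyl sulfur moved the number in this assay by a modest amount. A similarly modest step is expected here, without a firm direction, but leaning toward a somewhat higher number. This expectation corresponds to a 1.7-fold higher number from compound 2 to compound 3 (0.22 log units; within the scatter). Compound 3 is therefore estimated to give 10000 nM, within a range from 4000 nM to 25000 nM.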

Compound 3, concentration for 50% growth inhibition: 5900 nM
Compound 3: middle estimate off by 1.7-fold (0.23 log units), on the high side, and the stated range covers the measured number.
By their numbers in this assay, from the lowest: compounds 3 and 2 (each within the scatter of the next); then compound 1.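

In this assay, the exchange of 1-benzothiophen-6-yl for 4-chlorophenyl on the sulfonyl sulfur gives a 1.0-fold lower number from compound 2 to compound 3 (0.01 log units; within the scatter), so among these compounds the fused five-membered aromatic ring is not required to keep the number of compound 2. The step of a 2.2-fold lower number from compound 1 to compound 3 (0.34 log units; beyond the scatter) has the same size as the earlier step from that compound, which leaves the group in compound 1 as the one apart from two structurally different groups that sit within the scatter of each other. No measurement on hand explains these numbers.

On these data alone, whether an amine or a carboxylic acid in place of the chlorine of 4-chlorophenyl would keep the number stays open. The compounds shown also share the rest of the core, so they leave open what a longer chain would do.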